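Swapping Trifluoromethoxy for Trifluoromethyl on a Shared Core

The source may report more compounds than this note shows. Statements on the series, on what has been measured and on what is new or still open speak of the compounds shown alone.

Compound 1 `COc1ccc2cc(C(C)c3nnc4n3N=C(c3ccc(OC(F)(F)F)cc3)CS4)ccc2c1`: 8800 nM
Compound 2 `CC(C)Cc1ccc(C(C)c2n[nH]c(=S)n2N)cc1`: 16100 nM
Compound 3 `CC(C)Cc1ccc(C(C)c2nnc3n2N=C(c2ccc(Cl)cc2Cl)CS3)cc1`: 11800 nM

In a functional assay on MCF7 cells (Homo sapiens) for inhibition, read by sulforhodamine B assay, with a stated time of 72 h (a higher number here means a weaker inhibitor, a lower number a stronger inhibitor), compound 1 gives 8800 nM, the lowest of the three numbers, but compound 3 with 11800 nM and compound 2 with 16100 nM both lie within the usual scatter of that value, so no ordering among the three can be claimed. Compound 4 `COc1ccc2cc(C(C)c3nnc4n3N=C(c3ccc(C(F)(F)F)cc3)CS4)ccc2c1` differs from compound 1 by one change: trifluoromethyl in place of trifluoromethoxy on an aromatic carbon. Going by the values given here, no pair of measured compounds shows this kind of swap, so there is no measured step to lean on. The expectation is that the step in this assay stays within the scatter, with no clear direction. Compound 4 is estimated at 9000 nM, within a range of 3000 nM to 27000 nM, which means an expected step of a 1.0-fold higher number from compound 1 to compound 4 (0.01 log units; within the scatter).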

Compound 4, half-maximal inhibitory concentration: 6900 nM
The estimate for compound 4 lay 1.3-fold (0.12 log units) above the measured number; the range from low to high includes it.
By their numbers in this assay, from the lowest: compounds 4, 1, 3 and 2 (each within the scatter of the next, the first and the last beyond it).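

Going by these compounds alone, replacing 4-(trifluoromethoxy)phenyl with 4-(trifluoromethyl)phenyl on the shared core gives the first step between compounds that differ in one place. In this assay the swap gives a 1.3-fold lower number from compound 1 to compound 4 (0.11 log units; within the scatter) and so removing the oxygen at this position, para to a large group, produces no change that can be told from scatter. Nothing measured here offers a reason for this result. The compounds shown leave open whether a quite different group at this position, such as an amine or a carboxylic acid, would move the number beyond the scatter.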